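Changing the aryl group on the ring nitrogen

The compounds below may be only part of what the source reports. "The series", "measured", "known", "first", "only" and "open" are said of these compounds alone.

Compound 1: `Nc1scc(CN2CCN(c3ccc(OC(F)(F)F)cc3)CC2)c1C(=O)c1ccc(Cl)cc1` — in a functional assay on CHO cells with adenosine receptor A1 (Homo sapiens) as the target, read by cAMP accumulation and immunoassay, with a stated time of 6 min, tested at 0.1 uM (on this read-out lower numbers stand for a stronger effect and higher numbers for a weaker effect at the one concentration tested), compound 1 gives -13%.
Compound 2: `Nc1scc(CN2CCN(c3ccccc3F)CC2)c1C(=O)c1ccc(Cl)cc1` — in this assay compound 2 gives -1%.
Compound 3: `Nc1scc(CN2CCN(c3ccc(F)c(F)c3)CC2)c1C(=O)c1ccc(Cl)cc1` — in this assay compound 3 gives -34%.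

These three compounds share one core and differ only in the group attached to the amine nitrogen of the six-membered ring. Compound 3 stands lowest of the three numbers: its step from compound 1, a number 21 percentage points lower from compound 1 to compound 3 (beyond the scatter), and from compound 2, a number 33 percentage points lower from compound 2 to compound 3 (beyond the scatter), are both beyond the scatter, so it carries the strongest effect of the set.

The next compound is compound 4, `Nc1scc(CN2CCN(c3ccccc3Cl)CC2)c1C(=O)c1ccc(Cl)cc1`, not yet measured. It differs from compound 3 in one place: 2-chlorophenyl in place of 3,4-difluorophenyl on an amine nitrogen in a ring.

The step that bears most on this change is the one in the opposite direction, from compound 2 to compound 3, in which a 3,4-difluorophenyl took the place of a 2-fluorophenyl and the number fell by a number 33 percentage points lower from compound 2 to compound 3 (beyond the scatter). Going by the values given here, compound 4 carries a 2-chlorophenyl, a single halogen in the same position as in compound 2, so much of that fall is expected to reverse; the effect of chlorine in place of fluorine at that place has no measured example here.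

Compound 4 is therefore expected to sit well above compound 3, at an estimated -10%, with a range from -28% to 8%, which corresponds to an expected step of a number 24 percentage points higher from compound 3 to compound 4 (beyond the scatter).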

Compound 4, a percentage reported as activity, at one concentration (the size of the read-out at that concentration, not a potency): 2%
Beside the measured number, compound 4's estimate is 12 percentage points below it; the measured number falls inside the stated range.
By their numbers in this assay, from the lowest: compound 3; then compound 1; then compounds 2 and 4 (each within the scatter of the next).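

In this assay, the 2-chlorophenyl of compound 4 stands far from the 3,4-difluorophenyl, with a number 36 percentage points higher from compound 3 to compound 4 (beyond the scatter) showing that the low number of compound 3 does not carry over to this single-chlorine group. Going by these compounds alone, the first direct look at the halogen itself, a chloro in place of a fluoro on the same aromatic carbon, gives a number 3 percentage points higher from compound 2 to compound 4 (within the scatter) and so leaves the 2-fluorophenyl and 2-chlorophenyl compounds level. The 4-(trifluoromethoxy)phenyl group also differs from the 2-chlorophenyl, as a number 15 percentage points higher from compound 1 to compound 4 (beyond the scatter) shows, so among these four compounds the choice of aryl group matters more than the swap of fluoro for chloro, and compound 3 still holds the strongest effect, beyond the scatter of all three others.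

Still open, on these data alone, is which of the two fluorines in the 3,4-difluorophenyl goes with the low number, and how an unsubstituted phenyl or a phenyl bearing a methoxy group or an amine would read on this nitrogen. No measurement shown here explains why these aryl groups give such different numbers.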